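A smaller group on the carbonyl: from cyclopropyl to methoxy

The source may report more compounds than this note shows. Statements on the series, on what has been measured and on what is new or still open speak of the compounds shown alone.

Of the compounds shown here, three sharing one core have been measured in an assay on CHO cells for agonist activity at Neuronal acetylcholine receptor; alpha3/beta4 (Homo sapiens), read by FLIPR and calcium flux; a lower number here means a smaller maximal response, a higher number a larger maximal response. Compound 1 `C[C@H]1C[C@H]1C(=O)N1CC2CNCC2C1` gives 110%, the lowest of the three numbers. Compound 2 `C[C@@H]1C[C@@H]1C(=O)N1CC2CNCC2C1`, which carries the same atoms and bonds but differs in two of its stereocentres, gives 180%; compound 3 `CCC(=O)N1CC2CNCC2C1`, with ethyl on the carbonyl carbon, gives 130%. The step of a number 70 percentage points higher from compound 1 to compound 2 (beyond the scatter) is large, and the fact that one of compounds 1 and 2 is drawn with a defined configuration and the other without, at the place where they differ is what separates these two. The step of a number 20 percentage points higher from compound 1 to compound 3 (beyond the scatter) is modest, while a number 50 percentage points lower from compound 2 to compound 3 (beyond the scatter) runs the other way and is large.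

Compound 4 `COC(=O)N1CC2CNCC2C1` has not yet been measured. It differs from compound 1 in one place: methoxy in place of 2-methylcyclopropyl on a carbonyl carbon. The change most like it among the measured steps is the replacement of 2-methylcyclopropyl by ethyl, which raised the maximal response from compound 1 to compound 3 by a modest amount; the methoxy group is also a small, ring-free substituent on the same carbonyl carbon, and compound 3 sets a natural anchor. Removing the two stereocentres also removes the source of the large spread between compound 1 and compound 2.

Compound 4 is therefore expected to show a modest rise, a number 15 percentage points higher from compound 1 to compound 4 (beyond the scatter), in this assay. The estimate for compound 4 is 125%, in a range from 85% to 170%.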

Compound 4, largest response reached (Emax), in percent of the reference or control that the assay uses: 85%
Compound 4: the middle estimate sits 40 percentage points above what was measured, within the range that was stated.
By their numbers in this assay, from the lowest: compound 4; then compound 1; then compound 3; then compound 2.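

Among the earlier compounds, the ethyl group of compound 3 lay inside the span set by the two drawn forms of 2-methylcyclopropyl, whereas methoxy falls below that whole span in this assay. Going to methoxy gives a number 25 percentage points lower from compound 1 to compound 4 (beyond the scatter) and a number 95 percentage points lower from compound 2 to compound 4 (beyond the scatter), and since ethyl gave a rise from compound 1, losing the ring does not by itself fix the direction of change on this carbonyl carbon. The most telling comparison is a number 45 percentage points lower from compound 3 to compound 4 (beyond the scatter), where ethyl and methoxy match in heavy-atom count, so at this position the maximal response depends on which atoms the group holds, not only on how large it is.

From the compounds shown here alone, it remains open whether the fall belongs to the oxygen in particular or would also appear with other groups on this carbonyl carbon, such as a dimethylamino group or a longer chain like propyl. Nothing in the information available explains why methoxy gives a lower maximal response than ethyl or 2-methylcyclopropyl.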